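Compound 1 to Compound 4: Losing the Amino Link

The source may hold more compounds than are shown below. What is called first, only, known or untested is meant among the compounds shown, and "the series" means these compounds.

Compound 1 (`C=C[C@@](C)(/C=C/c1ccc(Nc2ccc(F)cc2)cc1)CCC=C(C)C`) is the starting point. In an ADME assay on HEK293 cells (Homo sapiens) for cytotoxicity, with a stated time of 72 h (on this read-out lower numbers stand for an effect already at smaller amounts and higher numbers for an effect only at larger amounts of compound), compound 1 gives > 36600 nM as a limit of the assay and not a number. Compound 2 (`C=C[C@@](C)(/C=C/c1ccc(Nc2c(F)cc(F)cc2F)cc1)CCC=C(C)C`) gives > 36600 nM as a limit as well. Compound 3 (`C=C[C@@](C)(/C=C/c1ccc(Nc2ccc(C(F)(F)F)cc2)cc1)CCC=C(C)C`) gives > 36600 nM as a limit too. Compound 1 therefore has no readable place among its neighbours, and the whole set shares one feature (the limit of > 36600 nM in this assay, at which 3 of the 3 values shown sit).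

Compound 4 (`C=C[C@@](C)(/C=C/c1ccc(-c2ccccc2)cc1)CCC=C(C)C`) has not yet been measured. It differs from compound 1 in one place (phenyl in place of (4-fluorophenyl)amino on an aromatic carbon), with phenyl in place of (4-fluorophenyl)amino on an aromatic carbon. Two measured changes touch the same group while keeping its nitrogen (a step that the two limits leave unreadable from compound 1 to compound 2; a step that the two limits leave unreadable from compound 1 to compound 3). Among the measured compounds shown here, neither has a size that can be read, and no measured step removes the nitrogen, so the evidence is thin. With compound 1 and both neighbours sitting at the same limit (the limit of > 36600 nM in this assay, at which 3 of the 3 values shown sit), no direction can be argued. In this assay the expected step (a step that the limit leaves unreadable from compound 1 to compound 4) is none beyond the scatter, and another limit is the likeliest report. Compound 4 is expected near 40000 nM, with an estimated range from 12000 nM to 100000 nM as its span.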

Compound 4, half-maximal effective concentration: > 36600 nM
Compound 4: a limit, no number; the forecaster's own chance of this, stated with the estimate: 75%; the middle value lies beyond the limit too.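

In this assay compound 4 gives > 36600 nM, which is a limit of the assay and not a number, so no step can be read between compound 1 and compound 4. The compounds shown leave open at what amount any of them would show cytotoxicity, and whether phenyl and (4-fluorophenyl)amino differ at all there: the limit of > 36600 nM in this assay, at which 4 of the 4 values shown sit.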